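This account rests on a few compounds, and the source may have more. Where it says the series, first, only, none or still open, it means among the compounds named here.

Compound 1 `O=C(Nc1cccc(-n2cc(-c3ccncc3)c(-c3ccc(Cl)c(O)c3)n2)c1)Nc1ccc(Cl)c(Cl)c1` in a functional assay on SK-MEL-2 cells (Homo sapiens) for inhibition, read by sulforhodamine B assay, with a stated time of 48 h (a lower number here means a stronger inhibitor of growth, a higher number a weaker inhibitor of growth), gives 1030 nM. This is the lowest of the three numbers measured here, yet it sits within the scatter of compound 3 `COc1cc(-c2nn(-c3cccc(NC(=O)c4cccc(C(F)(F)F)c4)c3)cc2-c2ccncc2)ccc1Cl`, which gives 1560 nM, and of compound 2 `COc1cc(-c2nn(-c3cccc(NC(=O)c4ccc(Cl)c(C(F)(F)F)c4)c3)cc2-c2ccncc2)ccc1Cl`, which gives 1900 nM. Among the compounds with values here, the only measured pair differing in one place, a 1.2-fold lower number from compound 2 to compound 3 (0.09 log units; within the scatter), moved nothing beyond the scatter. Compound 4 `O=C(Nc1cccc(-n2cc(-c3ccncc3)c(-c3ccc(Cl)c(O)c3)n2)c1)Nc1ccc(Cl)c(C(F)(F)F)c1` is compound 1 with a single change: trifluoromethyl in place of chloro on an aromatic carbon. Within the data shown here, no measured pair shows this exact exchange of chloro for trifluoromethyl, and the one nearby comparison that exists stayed flat, so the step of a 1.0-fold lower number from compound 1 to compound 4 (0.01 log units; within the scatter) is expected to remain within the scatter, in no particular direction. Compound 4 is therefore estimated at 1000 nM, with a range from 450 nM to 2300 nM.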

Compound 4, concentration for 50% growth inhibition: 798 nM
The estimate for compound 4 lay 1.3-fold (0.10 log units) above the measured number; the measured number falls inside the stated range.
By their numbers in this assay, from the lowest: compounds 4, 1, 3 and 2 (each within the scatter of the next, the first and the last beyond it).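

In this assay, trifluoromethyl in place of chloro, on the aromatic carbon ortho to a chloro group, gives a 1.3-fold lower number from compound 1 to compound 4 (0.11 log units; within the scatter). Within the data shown here, this is the first direct look at this exchange: a group of 4 heavy atoms can replace one of 1 heavy atom here without the number leaving the scatter. Nothing available explains this result. The compounds shown leave open whether this position stays as flat with a different kind of group, such as an amine, a carboxylic acid or a longer alkyl chain.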